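Adding chlorine to a hydroxyphenyl ring

A few compounds are considered here, and "the series" means these few. Any claim that something is new, unique, unknown or untested is made for them only; others in the source may bear on it.

Compound 1 `COc1cc(/C=C2\CCC/C(=C\c3ccc(F)c(F)c3)C2=O)cc(OC)c1OC` gives 2200 nM
Compound 2 `COc1cc(/C=C2\CCC/C(=C\c3cccc(O)c3)C2=O)cc(OC)c1OC` gives 6500 nM

Both values come from a functional assay on RKO cells (Homo sapiens) for antiproliferative activity, read by MTT assay, with a stated time of 72 h (on this read-out higher numbers stand for weaker inhibition and lower numbers for stronger inhibition), and so far there are only these two. Compound 2 at 6500 nM holds the higher number, which makes it the weaker inhibitor of the pair.

The next compound, not yet measured, is compound 3 `COc1cc(/C=C2\CCC/C(=C\c3ccc(O)c(Cl)c3)C2=O)cc(OC)c1OC` and it has 3-chloro-4-hydroxyphenyl in place of 3-hydroxyphenyl on a double-bonded chain carbon bound to a double-bonded ring carbon.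

For the measured compounds named here, only one measured step bears on this change, and only in part. That step is a 3.0-fold higher number from compound 1 to compound 2 (0.47 log units; beyond the scatter) and it came from putting 3-hydroxyphenyl in place of 3,4-difluorophenyl. Compound 3 keeps a hydroxy group like compound 2, yet its ring also carries chlorine, much as the ring of compound 1 carries fluorine. Its number is therefore expected to move toward compound 1 at 2200 nM without clearly passing it. No measured case here shows chlorine being added, so the expectation is loose.

The expected change is a 2.2-fold lower number from compound 2 to compound 3 (0.34 log units; beyond the scatter) as a modest move toward stronger inhibition. In this assay the estimate for compound 3 is 3000 nM within an expected range from 1000 nM to 8000 nM for a single measurement.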

Compound 3, half-maximal inhibitory concentration: 700 nM
Estimate against measurement, compound 3: 4.3-fold (0.63 log units) above; the measured number lies below the stated range.
By their numbers in this assay, from the lowest: compound 3; then compound 1; then compound 2.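

At this place, on a double-bonded chain carbon bound to a double-bonded ring carbon, the hydroxyphenyl ring is not tied to weak inhibition: in this assay, 3-chloro-4-hydroxyphenyl in place of 3-hydroxyphenyl gives a 9.3-fold lower number from compound 2 to compound 3 (0.97 log units; beyond the scatter). The same ring also outperforms the 3,4-difluorophenyl ring, with a 3.1-fold lower number from compound 1 to compound 3 (0.50 log units; beyond the scatter), so the ring carrying both chlorine and hydroxy gives the lowest number of the three, and the earlier pair gave no hint that a hydroxy-bearing ring could lead the set. Nothing available explains why this change has so large an effect.

This single step changes two things at once, since chlorine enters the ring and the hydroxy group goes from the 3 of the name to the 4, so the compounds shown cannot say how much of the gain belongs to each; a plain 4-hydroxyphenyl ring would help to separate them. On these data alone, it also remains open whether chlorine itself matters, or whether bromine or a methyl group in its place would give a similar number.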